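This account rests on a few compounds, and the source may have more. Where it says the series, first, only, none or still open, it means among the compounds named here.

Working notes on the series. In a functional assay on HCT-116 cells (Homo sapiens) for inhibition, read by CCK-8 assay, with a stated time of 72 h, tested at 2 uM (on this read-out higher numbers stand for more inhibition of growth at the one concentration tested and lower numbers for less inhibition of growth), compound 1 (`Nc1ccccc1NC(=O)/C=C/c1ccc(CSc2ccc(Cl)cc2)cc1`) stands at 5.62% and compound 2 (`Nc1ccccc1NC(=O)c1ccc(CSc2cccc(F)c2)cc1`) at 5.5% on the same read-out. These two values lie within the usual scatter of each other, so compound 2 cannot be placed apart from compound 1. Compound 3 (`Nc1ccccc1NC(=O)c1ccc(CSc2ccc(Cl)cc2)cc1`) carries 4-chlorophenyl in place of 3-fluorophenyl on a sulfur. Going by the values given here, no step between measured compounds shows what a change at this place does. Since compound 1 gives 5.62% in this assay with 4-chlorophenyl on a sulfur on a different core, no step beyond the scatter is expected in either direction. The expected change is a number 2.5 percentage points higher from compound 2 to compound 3 (within the scatter) and it is expected to stay within the scatter. Compound 3 is estimated at 8% with an expected range from 1% to 25% on this read-out.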

Compound 3, percent growth inhibition at one concentration: 17.5%
Compound 3: middle estimate off by 9.5 percentage points, on the low side, within the range that was stated.
By their numbers in this assay, from the lowest: compounds 2 and 1 (each within the scatter of the next); then compound 3.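

Going by these compounds alone, this is the first readable step at this place: in this assay, on a sulfur whose other neighbour is a saturated chain carbon, 4-chlorophenyl in place of 3-fluorophenyl gives a number 12 percentage points higher from compound 2 to compound 3 (beyond the scatter) on an otherwise unchanged structure. The group on the sulfur can therefore shift growth inhibition beyond the usual scatter, though the step is modest and rests on a single pair. Nothing at hand gives a reason for this step.

The change alters the halogen and its place on the ring together, so the compounds shown cannot tell which of the two matters. Also open, from the compounds shown here alone, is how a plain phenyl, a methoxy-bearing phenyl or an amine-bearing phenyl would read at this place, and whether the step carries over to the core of compound 1.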